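The source may hold more compounds than are shown below. What is called first, only, known or untested is meant among the compounds shown, and "the series" means these compounds.

Two compounds sharing one core have so far been examined in an assay on isolated protein for inhibition of histone deacetylase 8 (Homo sapiens), with a stated time of 1 h; on this read-out lower numbers stand for stronger inhibition and higher numbers for weaker inhibition. Compound 1 `COc1cccc(NC(=O)COc2ccc3cc(/C=C4/SC(=O)NC4=O)ccc3c2)c1` gives 7600 nM in this assay, the higher of the two numbers seen so far. Compound 2 `O=C(COc1ccc2cc(/C=C3/SC(=O)NC3=O)ccc2c1)Nc1ccccc1` gives 4500 nM in this assay, and the step of a 1.7-fold lower number from compound 1 to compound 2 (0.23 log units; within the scatter) lies within the scatter, so the two compounds cannot be told apart on this read-out. Compound 3 `O=C(COc1ccc2cc(/C=C3/SC(=O)NC3=O)ccc2c1)Nc1ccc(F)cc1` has not yet been measured. It differs from compound 1 in one place: 4-fluorophenyl in place of 3-methoxyphenyl on an amide-type nitrogen. Within the data shown here, the only measured step that bears on this change is the one from compound 1 to compound 2, hydrogen in place of methoxy on an aromatic carbon, and that step was small. Among the measured compounds shown here, the change to compound 3 goes one part further, as a 4-fluorophenyl enters rather than a plain phenyl, and no measured pair speaks to that part on its own. A step of similar size is therefore expected, a 1.7-fold lower number from compound 1 to compound 3 (0.23 log units; within the scatter), with no clear direction beyond the scatter. Compound 3 is estimated at 4500 nM, with a range from 2000 nM to 10000 nM.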

Compound 3, half-maximal inhibitory concentration: 6600 nM
Estimate against measurement, compound 3: 1.5-fold (0.17 log units) below, within the range that was stated.
By their numbers in this assay, from the lowest: compounds 2, 3 and 1 (each within the scatter of the next).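

In this assay, 4-fluorophenyl in place of 3-methoxyphenyl on the amide-type nitrogen gives a 1.2-fold lower number from compound 1 to compound 3 (0.06 log units; within the scatter) and fluoro in place of hydrogen on an aromatic carbon gives a 1.5-fold higher number from compound 2 to compound 3 (0.17 log units; within the scatter) as the second step, and both lie within the scatter. The earlier pair showed only that removing the methoxy made no clear difference, whereas this result adds a fluoro-bearing ring, so three different aromatic groups on this nitrogen (3-methoxyphenyl, phenyl and 4-fluorophenyl) now cannot be told apart on this read-out. No independent evidence bears on this result, so it offers no explanation for why these groups read alike.

On these data alone, all three compounds carry a six-membered aromatic ring of carbon only on this nitrogen, so it remains open whether a pyridine ring, a saturated cyclohexyl group or a longer chain between the nitrogen and the ring would give a step beyond the scatter. It also remains open whether an amine or a carboxylic acid on the ring would do so, since methoxy and fluoro are the only ring substituents shown here.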